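Nitro for Hydroxy on a Shared Semicarbazone Core

The source may report more compounds than this note shows. Statements on the series, on what has been measured and on what is new or still open speak of the compounds shown alone.

Compound 3 `C/C(=N/NC(=O)Nc1nnc(COc2ccc3ccccc3c2)o1)c1ccc(O)cc1` is one of three related semicarbazones tested in a functional assay on the whole organism (strain Swiss albino) with Mus musculus as the target, in the maximal electroshock model, with a stated time of 0.5 h; a higher number here means that more compound is needed for the effect, a lower number that less compound is needed. In this assay compound 3 gives 100 mg/kg, compound 1 `O=C(N/N=C\c1ccc(O)cc1)Nc1nnc(COc2ccc3ccccc3c2)o1` gives 100 mg/kg, and compound 2 `O=C(N/N=C(/c1ccccc1)c1ccc(O)cc1)Nc1nnc(COc2ccc3ccccc3c2)o1` gives 100 mg/kg. The step of no change at the digits printed from compound 1 to compound 3 (within the scatter) and the step of no change at the digits printed from compound 2 to compound 3 (within the scatter) both stay within the scatter, so compound 3 stands level with the other two.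

Compound 4 `C/C(=N/NC(=O)Nc1nnc(COc2ccc3ccccc3c2)o1)c1ccc([N+](=O)[O-])cc1` differs from compound 3 in one place: nitro in place of hydroxy on an aromatic carbon. For the measured compounds named here, no measured step touches this hydroxyphenyl to nitrophenyl exchange, and the two steps that are known, both flat, concern other parts of the molecule. With nothing pointing either way, no change beyond the scatter is expected, no change at the digits printed from compound 3 to compound 4 (within the scatter). Compound 4 is therefore estimated at 100 mg/kg, within 50 mg/kg to 300 mg/kg.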

Compound 4, minimum effective dose: 100 mg/kg
Compound 4: the middle estimate sits on the measured number at the digits printed, within the range that was stated.
By their numbers in this assay, from the lowest: compounds 1, 2, 3 and 4 (each within the scatter of the next).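

At the aromatic carbon para to a large group, nitro in place of hydroxy gives no change at the digits printed from compound 3 to compound 4 (within the scatter) in this assay. For the compounds shown here, the earlier steps touched only the group on the carbon with a double bond to nitrogen, so this is the first reading at this ring position, and in this pair the hydroxy group is not required for the read-out. Nothing available explains this flat result.

Going by these compounds, whether an amine or a carboxylic acid at this position would stand level with compound 3 remains open, as does whether the same exchange gives the same result on the cores of compound 1 and compound 2.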